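A fluorine-bearing phenyl in place of a methylphenyl

The compounds below may be only part of what the source reports. "The series", "measured", "known", "first", "only" and "open" are said of these compounds alone.

Compound 1 `CCCSc1nc(N/N=C/c2ccc(C)cc2)c2nnn(Cc3ccccc3)c2n1` reaches only the assay limit in a functional assay on ECa-109 cells (Homo sapiens) for antiproliferative activity, read by MTT assay, with a stated time of 72 h; on this read-out higher numbers stand for weaker inhibition and lower numbers for stronger inhibition: compound 1 gives > 64000 nM, which is a limit rather than a number. In this assay compound 2 `C#CCSc1nc(N/N=C(\C)c2ccccc2O)c2nnn(Cc3ccccc3)c2n1` gives 5250 nM, and compound 3 `C/C(=N\Nc1nc(SCc2ccccc2)nc2c1nnn2Cc1ccccc1)c1ccccc1O` gives 1770 nM. Among the measured compounds shown here, the only measured step, a 3.0-fold lower number from compound 2 to compound 3 (0.47 log units; beyond the scatter), concerns the chain bound to sulfur and not the site altered here. Compound 4 `CCCSc1nc(N/N=C/c2ccccc2F)c2nnn(Cc3ccccc3)c2n1` differs from compound 1 by 2-fluorophenyl in place of 4-methylphenyl on a carbon with a double bond to nitrogen. For the measured compounds named here, no measured step bears on this exchange, so no shift beyond the scatter is expected from it. Compound 1 stands at the limit of > 64000 nM in this assay, at which 1 of the 3 values shown sits. Compound 4 is therefore estimated at about 64000 nM, within 15000 nM to 250000 nM. The expected step of a number no higher from compound 1 to compound 4 (the limit leaves the size open) is small, and a limit alone is again likely.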

Compound 4, half-maximal inhibitory concentration: > 64000 nM
Compound 4: no number, only a limit; the forecaster's own chance of this, stated with the estimate: 60%; the middle value sits exactly at the limit.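

In this assay compound 4, like compound 1, gives only a limit and not a number, so the step between them cannot be read. The compounds shown leave open whether 2-fluorophenyl in place of 4-methylphenyl changes inhibition at all.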